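One amide group swapped, with one value to go on

The source may hold more compounds than are shown below. What is called first, only, known or untested is meant among the compounds shown, and "the series" means these compounds.

- compound 1 `N[C@H]1CC[C@H](Nc2c(C(=O)NCc3ccc(F)cc3)nc(Br)c3cccnc23)CC1` gives "not determined" (no result reported)
- compound 2 `CN(C)c1ccc(CNC(=O)c2nc(Br)c3cccnc3c2N[C@H]2CC[C@H](N)CC2)cc1` gives 5300 nM

Going by the values given here, in a functional assay on HEY cells (Homo sapiens) for cytotoxicity, read by MTT assay, with a stated time of 72 h (on this read-out lower numbers stand for stronger inhibition and higher numbers for weaker inhibition), compound 2 gives 5300 nM as the only number available, so it cannot yet be ranked against anything. Compound 3 `C[C@H](NC(=O)c1nc(Br)c2cccnc2c1N[C@H]1CC[C@H](N)CC1)c1ccc(F)cc1` keeps the shared core and changes one group, as counted in 1-(4-fluorophenyl)ethyl in place of 4-(dimethylamino)benzyl on an amide-type nitrogen here: 1-(4-fluorophenyl)ethyl in place of 4-(dimethylamino)benzyl on an amide-type nitrogen. Among the compounds with values here, no measured step between related compounds is available as a guide, so no shift beyond the usual scatter is expected, in either direction. The expected change is a 1.2-fold lower number from compound 2 to compound 3 (0.07 log units; within the scatter) in size. The estimated value for compound 3 is 4500 nM within an expected range of 1300 nM to 15000 nM for repeat measurements.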

Compound 3, half-maximal inhibitory concentration: > 10000 nM
Compound 3 was reported as a limit; the forecaster's own chance of this, stated with the estimate: 10%; at least 2.2-fold (0.34 log units) between middle value and limit.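

In this assay compound 3 gives > 10000 nM, which is a limit and not a number. Going by these compounds alone, this gives the first comparison on the amide-type nitrogen: replacing 4-(dimethylamino)benzyl with 1-(4-fluorophenyl)ethyl produces an at least 1.8-fold higher number from compound 2 to compound 3 (0.27 log units; that floor lies within the scatter), so this change brings no sign of stronger inhibition. The comparison rests on one bound rather than on two numbers: the limit of > 10000 nM in this assay, at which 1 of the 3 values shown sits.

What the compounds shown leave open is how a plain benzyl group, or a longer chain ending in an amine, would read on this nitrogen in this assay.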